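This account rests on a few compounds, and the source may have more. Where it says the series, first, only, none or still open, it means among the compounds named here.

Measured so far:
- compound 1, `COc1ccc(C(=O)/C=C/c2cc3cc(C)ccc3nc2Cl)cc1`: 20500 nM
- compound 2, `Cc1ccc2nc(Cl)c(/C=C/C(=O)c3cccs3)cc2c1`: 740 nM

In a functional assay for antagonist activity at metabotropic glutamate receptor 1 (Rattus norvegicus), read by scintillation counting and inositol phosphate accumulation (a higher number here means a weaker inhibitor, a lower number a stronger inhibitor), compound 1 gives 20500 nM and compound 2 gives 740 nM, so compound 2 stands at the lower of the two numbers, the stronger inhibitor. Among the compounds with values here, the single step available, a 28-fold lower number from compound 1 to compound 2 (1.44 log units; beyond the scatter), shows that the aromatic group on the carbonyl carbon can shift the result a long way.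

Compound 3, `Cc1ccc2nc(Cl)c(/C=C/C(=O)c3ccccc3)cc2c1`, is the next variation at that same position: phenyl in place of thiophen-2-yl on a carbonyl carbon. Within the data shown here, no measured pair shows this exact exchange, so the only guide is that step from compound 1 to compound 2, which points to the carbonyl-bound ring as a sensitive spot. With phenyl sitting between the two rings already tested, compound 3 is expected to land somewhat weaker than compound 2, an estimated step of a 2.0-fold higher number from compound 2 to compound 3 (0.31 log units; beyond the scatter) in this assay. The estimate for compound 3 is 1500 nM, with a range of 400 nM to 6000 nM.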

Compound 3, half-maximal inhibitory concentration: 1700 nM
Beside the measured number, compound 3's estimate is 1.1-fold (0.05 log units) below it; measured number inside the range.
By their numbers in this assay, from the lowest: compound 2; then compound 3; then compound 1.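

In this assay, a 2.3-fold higher number from compound 2 to compound 3 (0.36 log units; beyond the scatter) shows that exchanging the five-membered sulfur ring for a plain six-membered carbon ring on the carbonyl carbon has only a modest effect. Compound 3 also separates the two changes that were combined in the first step: a 12-fold lower number from compound 1 to compound 3 (1.08 log units; beyond the scatter) comes from replacing methoxy with hydrogen on an aromatic carbon, so among these compounds, most of the weakness of compound 1 goes with the methoxy group rather than with having a phenyl ring. No measurement offered here explains either step.

The compounds shown leave open how a furan-2-yl ring on the carbonyl carbon would compare with thiophen-2-yl and phenyl. They also leave open whether fluorine or an amine on that aromatic carbon would raise the number as far as methoxy does.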